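This account rests on a few compounds, and the source may have more. Where it says the series, first, only, none or still open, it means among the compounds named here.

Measured so far:

compound 1 `Cc1cc(C)c(Nc2ccc(Cl)c(Cl)c2)c(C)c1` — 1100 nM
compound 2 `Cc1cc(C)c(Nc2ccc(Cl)c(C(F)(F)F)c2)c(C)c1` — 400 nM
compound 3 `Cc1cc(C)c(Nc2cc(C)ccc2C)c(C)c1` — 1800 nM

All three compounds were tested in an assay on isolated protein for binding affinity to Rap guanine nucleotide exchange factor 4 (Homo sapiens), read by cAMP accumulation; on this read-out lower numbers stand for stronger inhibition and higher numbers for weaker inhibition. Among them compound 2 gives the lowest number, 400 nM, with compound 1 at 1100 nM and compound 3 at 1800 nM both higher by more than the usual scatter. Among the measured compounds shown here, the one single-point step seen so far runs from compound 1 to compound 2, a 2.8-fold lower number from compound 1 to compound 2 (0.44 log units; beyond the scatter), where a trifluoromethyl group replaces a chloro group.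

Compound 4 `Cc1cc(C)c(Nc2cccc(C(F)(F)F)c2)c(C)c1` has not yet been measured. Compared with compound 2 the change is hydrogen in place of chloro on an aromatic carbon. For the measured compounds named here, no measured pair shows what removing a chloro group alone does here; the step from compound 1 to compound 2 concerns an exchange of groups, not a loss. The expectation for compound 4 is therefore a somewhat weaker result than compound 2, a modest 2.0-fold higher number from compound 2 to compound 4 (0.30 log units; within the scatter). The estimated value for compound 4 in this assay is 800 nM, with a range from 300 nM to 2200 nM.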

Compound 4, half-maximal inhibitory concentration: 2000 nM
Compound 4: the middle estimate sits 2.5-fold (0.40 log units) below what was measured, and the stated range covers the measured number.
By their numbers in this assay, from the lowest: compound 2; then compounds 1, 3 and 4 (each within the scatter of the next).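

Replacing the chloro group ortho to a trifluoromethyl group with hydrogen gives a 5.0-fold higher number from compound 2 to compound 4 (0.70 log units; beyond the scatter) in this assay and so weakens inhibition. Among the compounds shown here, the earlier step showed only one group exchanged for another, whereas this one shows that leaving this position with hydrogen alone costs more than the usual scatter, so a group here counts for compound 2. Nothing measured here explains why the chloro group matters at this position.

Going by these compounds, whether a different group at the same place, such as a methoxy group, an amine or a nitrile, would keep the number as low as in compound 2 remains open. Also open, on these data alone, is whether removing the trifluoromethyl group and keeping the chloro group would cost as much.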